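Removing one methyl from compound 2

The compounds below may be only part of what the source reports. "The series", "measured", "known", "first", "only" and "open" are said of these compounds alone.

In a functional assay on ME-180 cells (Homo sapiens) for antiproliferative activity, read by MTT assay (on this read-out lower numbers stand for stronger inhibition and higher numbers for weaker inhibition), compound 1 (`Cc1nn2c(-c3nc4cc(C)c(C)cc4[nH]3)c(-c3ccccc3)nc2s1`) gives 19900 nM, while compound 2 (`Cc1ccc2[nH]c(-c3c(-c4ccc(F)cc4)nc4sc(C)nn34)nc2c1`) gives 6600 nM, the lower of the two numbers, by a gap beyond the usual scatter. Compound 3 (`Cc1nn2c(-c3nc4ccccc4[nH]3)c(-c3ccc(F)cc3)nc2s1`) has not yet been measured. It differs from compound 2 in one place: hydrogen in place of methyl on an aromatic carbon. Going by the values given here, no measured pair shows this change on its own, so only a small expected step, a 1.2-fold higher number from compound 2 to compound 3 (0.08 log units; within the scatter), is proposed, towards a slightly higher number and within the scatter. Compound 3 is expected at 8000 nM, with an estimated range from 3000 nM to 20000 nM.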

Compound 3, half-maximal inhibitory concentration: 18100 nM
The estimate for compound 3 lay 2.3-fold (0.35 log units) below the measured number; the measured number falls inside the stated range.
By their numbers in this assay, from the lowest: compound 2; then compounds 3 and 1 (each within the scatter of the next).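

In this assay the methyl on the six-membered carbon ring of the fused system does count: replacing it with hydrogen brings a 2.7-fold higher number from compound 2 to compound 3 (0.44 log units; beyond the scatter) and this modest step lies beyond the scatter. Going by these compounds alone, it is the first view of this change on its own, as no earlier pair isolated it. Nothing measured here accounts for the step. Still open, as far as these compounds go, is whether another group on this carbon, such as chlorine or a methoxy group, would give a lower number than methyl does, and whether the same step would appear on other members.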